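The compounds below may be only part of what the source reports. "The series", "measured", "known", "first", "only" and "open" are said of these compounds alone.

Measured so far:
- Compound 1 `Cc1nc(C)c([C@H](OC(C)(C)C)C(=O)O)c(N2CCC(C)(C)CC2)c1-c1ccc(OCCc2cc(F)c(F)cc2F)cc1`: >= 33500 nM
- Compound 2 `Cc1nc(C)c([C@H](OC(C)(C)C)C(=O)O)c(N2CCC(C)(C)CC2)c1-c1ccc(SCCc2ccc(F)cc2)cc1`: >= 32000 nM

Both compounds were tested in a toxicity assay on MT2 cells (Homo sapiens) for cytotoxicity, read by XTT assay, with a stated time of 4 days (a higher number here means that more compound is tolerated, a lower number that less compound is tolerated), and neither gave an exact number. Compound 2 stands at a limit of the assay, >= 32000 nM. Compound 1 also stands at a limit, >= 33500 nM.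

The next compound, compound 3 `Cc1nc(CCOc2ccc(-c3c(C)nc(C)c([C@H](OC(C)(C)C)C(=O)O)c3N3CCC(C)(C)CC3)cc2)cs1`, keeps the shared core. It has 2-(2-methyl-1,3-thiazol-4-yl)ethoxy in place of (2-(4-fluorophenyl)ethyl)sulfanyl, on an aromatic carbon para to a large group: 2-(2-methyl-1,3-thiazol-4-yl)ethoxy in place of (2-(4-fluorophenyl)ethyl)sulfanyl on an aromatic carbon.

Among the measured compounds shown here, only one measured step bears on this change, as it alters the group on the same aromatic carbon. That step is a step that the two limits leave unreadable from compound 1 to compound 2, so it offers no size to carry over. What remains is that neither group tested at this carbon gave a number in this assay. No step beyond the scatter is therefore expected, and no direction can be argued. The assay may well report only a limit again. The estimate amounts to an expected at least 1.0-fold lower number from compound 2 to compound 3 (0.02 log units; that floor lies within the scatter). Compound 3 is expected at about 30000 nM, with an estimated range of 10000 nM to 40000 nM.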

Compound 3, half-maximal cytotoxic concentration: >= 25000 nM
Compound 3 was reported as a limit (the forecaster's own chance of this, stated with the estimate: 70%); the middle value is on the limit's open side.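

In this assay compound 3 gives only a limit, >= 25000 nM. Compound 1 and compound 2 also stand at limits, so no step can be read among compound 1, compound 2 and compound 3. The compounds shown leave open the exact concentration at which each becomes toxic to the cells, and whether changing the group on this aromatic carbon alters it.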